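The source may hold more compounds than are shown below. What is called first, only, known or untested is meant among the compounds shown, and "the series" means these compounds.

Of the compounds shown here, three have numbers so far in a functional assay on MDA-MB-435 cells (Homo sapiens) for inhibition, read by sulforhodamine B assay, with a stated time of 48 h (on this read-out lower numbers stand for stronger inhibition of growth and higher numbers for weaker inhibition of growth), for this series. Compound 1 (`O=C(Nc1cccc(-n2cc(-c3ccncc3)c(-c3ccc(Cl)c(O)c3)n2)c1)Nc1cccc(C(F)(F)F)c1`) stands at 1490 nM and compound 2 (`COc1cc(-c2nn(-c3cccc(NC(=O)Nc4cc(C(F)(F)F)cc(C(F)(F)F)c4)c3)cc2-c2ccncc2)ccc1Cl`) stands at 886 nM while compound 3 (`COc1cc(-c2nn(-c3cccc(NC(=O)Nc4ccc(Cl)c(Cl)c4)c3)cc2-c2ccncc2)ccc1Cl`) stands at 938 nM on the same read-out. These three values lie within the scatter of one another, so compound 1 is not separated from either of the other two and no order can be drawn among them. Among the measured compounds shown here, no pair of measured compounds differs in one place only, which leaves no measured step to lean on.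

The next compound is compound 4 (`O=C(Nc1cccc(-n2cc(-c3ccncc3)c(-c3ccc(Cl)c(O)c3)n2)c1)Nc1ccc(Cl)c(Cl)c1`), which has 3,4-dichlorophenyl in place of 3-(trifluoromethyl)phenyl on an amide-type nitrogen. For the measured compounds named here, the only evidence on the entering group comes from compound 3, which also carries 3,4-dichlorophenyl on an amide-type nitrogen. Compound 3 at 938 nM lies within the scatter of compound 1 at 1490 nM and differs from it in more than that group. On this basis, no step beyond the scatter is expected in this assay in either direction. The estimated step of a 1.2-fold lower number from compound 1 to compound 4 (0.09 log units; within the scatter) is accordingly small. For compound 4 the expected value is 1200 nM (estimated range 600 nM to 2400 nM).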

Compound 4, concentration for 50% growth inhibition: 1100 nM
Compound 4: middle estimate off by 1.1-fold (0.04 log units), on the high side; low and high end bracket the measured number.
By their numbers in this assay, from the lowest: compounds 2, 3, 4 and 1 (each within the scatter of the next).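

In this assay, the exchange of 3-(trifluoromethyl)phenyl for 3,4-dichlorophenyl on an amide-type nitrogen now has a matched reading, a 1.4-fold lower number from compound 1 to compound 4 (0.13 log units; within the scatter), so these two groups are not separated at this position on the shared core. The series also gains a second matched reading, at the oxygen on an aromatic ring: with 3,4-dichlorophenyl held constant, hydrogen in place of methyl gives a 1.2-fold higher number from compound 3 to compound 4 (0.07 log units; within the scatter), so the hydroxy and methoxy forms are not separated either. Nothing measured here bears on the reason these two changes leave the read-out within the scatter.

As far as these compounds go, both readings cover only a narrow set of substituents, so it remains open whether the number would hold with a basic amine such as a dimethylamino group, or a carboxylic acid, on the phenyl ring attached to the amide-type nitrogen. From the compounds shown here alone, it is equally open whether a longer chain on the oxygen on an aromatic ring, such as ethyl or propyl, would produce a step beyond the scatter in this assay.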